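Swapping the halogenated phenyl group of compound 2

The compounds below may be only part of what the source reports. "The series", "measured", "known", "first", "only" and "open" are said of these compounds alone.

Compound 1 `CN1CCN(c2ccc(Nc3ncc4nc(Nc5cccc(Cl)c5)n(C5CCCC5)c4n3)cc2)CC1` gives < 0.01 nM as a limit
Compound 2 `CN1CCN(c2ccc(Nc3ncc4nc(Nc5ccc(Br)cc5F)n(C5CCCC5)c4n3)cc2)CC1` gives 2.3 nM as a number

Among the measured compounds shown here, in a functional assay on HCC827 cells (Homo sapiens) for cytotoxicity, read by MTT assay, with a stated time of 72 h (on this read-out higher numbers stand for weaker inhibition and lower numbers for stronger inhibition), compound 2 gives 2.3 nM as the only true number so far. Compound 1 gives < 0.01 nM in this assay as a limit of the assay and not a number.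

Compound 3 `CN1CCN(c2ccc(Nc3ncc4nc(Nc5cc(Cl)ccc5Cl)n(C5CCCC5)c4n3)cc2)CC1` has not been measured yet. Its difference from compound 2 is 2,5-dichlorophenyl in place of 4-bromo-2-fluorophenyl on a nitrogen on an aromatic ring with 2,5-dichlorophenyl in place of 4-bromo-2-fluorophenyl on a nitrogen on an aromatic ring.

For the measured compounds named here, the one measured step that bears on this place is an at least 230-fold higher number from compound 1 to compound 2 (2.36 log units; beyond the scatter) and it is large, with 4-bromo-2-fluorophenyl in place of 3-chlorophenyl. Compound 3 loses that 4-bromo-2-fluorophenyl and again carries a chlorinated phenyl, so a lower number is expected in this assay but not the full return, since 2,5-dichlorophenyl is not 3-chlorophenyl. The expected change is a 4.6-fold lower number from compound 2 to compound 3 (0.66 log units; beyond the scatter) as estimated from this single step. For compound 3 the estimate is 0.5 nM with an expected range from 0.05 nM to 5 nM in this assay for now.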

Compound 3, half-maximal inhibitory concentration: 0.01 nM
The estimate for compound 3 lay 50-fold (1.70 log units) above the measured number; the whole stated range lies above it.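

In this assay, among the compounds shown here, this position now shows a 230-fold lower number from compound 2 to compound 3 (2.36 log units; beyond the scatter), the first step here with a true number at both ends. The exchange leaves the heavy-atom count and the counts of hydrogen-bond donors and acceptors unchanged, so a step of this size at the nitrogen goes with the identity of the halogenated phenyl group and not with those counts, and the 2,5-dichlorophenyl group shows that the very low numbers are not confined to the 3-chlorophenyl group. Compound 1 stands at a limit and not a number. Chloro in place of hydrogen on an aromatic carbon gives a number no lower from compound 1 to compound 3 (the limit leaves the size open), so this step cannot be read in size: the limit of < 0.01 nM in this assay, at which 1 of the 3 values shown sits.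

Going by these compounds, what remains open is whether the bromo or the fluoro of the 4-bromo-2-fluorophenyl group goes with the higher number of compound 2, since the two are exchanged together here. On these data alone, it is equally open whether a methoxy group or a nitrile on this phenyl ring, in place of the halogens, would keep the number as low as that of compound 3.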